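Amide Swap at the Carbonyl: Morpholine to Carbamoylpiperidine

The source may report more compounds than this note shows. Statements on the series, on what has been measured and on what is new or still open speak of the compounds shown alone.

Compound 1 `C/C=C/Cn1cc(-c2ccc(C(=O)N3CCN(S(C)(=O)=O)CC3)c(Cl)c2)n2cncc2c1=O` gives 6630 nM in a functional assay on A549 cells (Homo sapiens) for antiproliferative activity; on this read-out higher numbers stand for weaker inhibition and lower numbers for stronger inhibition. Compound 2 `C/C=C/Cn1cc(-c2ccc(C(=O)N3CCOCC3)c(Cl)c2)n2cncc2c1=O` reaches only a limit of the assay, > 10000 nM, in this assay.

As far as these compounds go, compound 2 thus stands at the weak end of what has been measured, at the limit of > 10000 nM in this assay, at which 1 of the 2 values shown sits, and its true number beyond that boundary is unknown. The change to compound 3 `C/C=C/Cn1cc(-c2ccc(C(=O)N3CCC(C(N)=O)CC3)c(Cl)c2)n2cncc2c1=O` is 4-carbamoylpiperidin-1-yl in place of morpholin-4-yl on a carbonyl carbon. For the measured compounds named here, only one measured step touches this carbonyl carbon: an at least 1.5-fold higher number from compound 1 to compound 2 (0.17 log units; that floor lies within the scatter). That step runs from a measured number to a limit, and its floor lies within the usual scatter, so it gives no firm direction for exchanging groups at this carbonyl. Nothing measured points to a gain for the 4-carbamoylpiperidin-1-yl group, and nothing points to a loss beyond the scatter either. Compound 3 is therefore expected to land close to where compound 2 sits in this assay, with a real chance that it too returns only a limit. Compound 3 is estimated at 9000 nM, with a range from 3000 nM to 30000 nM. The step expected is an at least 1.1-fold lower number from compound 2 to compound 3 (0.04 log units; that floor lies within the scatter).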

Compound 3, half-maximal inhibitory concentration: 7150 nM
Compound 3: the middle estimate sits 1.3-fold (0.10 log units) above what was measured; measured number inside the range.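

For the compounds shown here, at this carbonyl carbon, compound 3 allows the first comparison between two measured numbers: replacing the 4-(methylsulfonyl)piperazin-1-yl group with the 4-carbamoylpiperidin-1-yl group gives a 1.1-fold higher number from compound 1 to compound 3 (0.03 log units; within the scatter), so this assay does not tell these two amides apart, even though the incoming group carries a hydrogen-bond donor. Set against the morpholin-4-yl group, the change gives an at least 1.3-fold lower number from compound 2 to compound 3 (0.14 log units; that floor lies within the scatter); this is only a floor, so the real gap may be small or may be larger. Compound 2 remains a limit and not a number: the limit of > 10000 nM in this assay, at which 1 of the 3 values shown sits.

As far as these compounds go, it remains open whether a piperidine bearing a carboxylic acid or an amine in place of the carbamoyl group, or a simple dimethylamine amide, would move the number at this carbonyl carbon clearly beyond the scatter in this assay. Also open, from the compounds shown here alone, is how weak compound 2 truly is, and therefore whether the morpholin-4-yl group really differs from the other two groups.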